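The source may hold more compounds than are shown below. What is called first, only, known or untested is meant among the compounds shown, and "the series" means these compounds.

Within the data shown here, in a functional assay on SW480 cells (Homo sapiens) for antiproliferative activity, read by MTT assay, with a stated time of 48 h (on this read-out lower numbers stand for stronger inhibition and higher numbers for weaker inhibition), compound 1 `CCCCCCC(CCO)n1cnc2c(Cl)nc(F)nc21` gives 12900 nM and compound 2 `CCCCCCCC(CCO)n1cnc2c(Cl)nc(F)nc21` gives 26100 nM, the higher of the two numbers so far. Compound 3 `CC(C)(C)[Si](C)(C)OCC(CCO)n1cnc2c(Cl)nc(F)nc21` has not yet been measured. Its difference from compound 2 is a group of 8 heavy atoms (6 carbon, 1 oxygen, 1 silicon; no ring) in place of a group of 6 heavy atoms (6 carbon; no ring), on a saturated chain carbon, two bonds along the chain from an aromatic nitrogen, and the exchange sits on a saturated chain carbon, two bonds along the chain from an aromatic nitrogen. Among the measured compounds shown here, only one measured step bears on this, and only loosely: a 2.0-fold higher number from compound 1 to compound 2 (0.31 log units; beyond the scatter), a modest step. For the measured compounds named here, no measured compound carries oxygen or silicon in this group, so the direction remains uncertain. A step of similar modest size is expected in this assay, leaning slightly toward a lower number. The expected change is a 1.5-fold lower number from compound 2 to compound 3 (0.16 log units; within the scatter). For compound 3 the estimated value is 18000 nM, with a range from 7000 nM to 45000 nM.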

Compound 3, half-maximal inhibitory concentration: 8020 nM
Compound 3: the middle estimate sits 2.2-fold (0.35 log units) above what was measured, and the stated range covers the measured number.
By their numbers in this assay, from the lowest: compounds 3 and 1 (each within the scatter of the next); then compound 2.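

In this assay, the group holding oxygen and silicon on this saturated chain carbon, in place of hexyl, gives a 3.3-fold lower number from compound 2 to compound 3 (0.51 log units; beyond the scatter), which shows that the position tolerates a group that is not all carbon and has a hydrogen-bond acceptor, something the earlier carbon-only chains could not show. Set against the five-carbon group, the same group gives a 1.6-fold lower number from compound 1 to compound 3 (0.21 log units; within the scatter), so those two groups cannot be told apart here, and only the hexyl compound stands apart from them. Nothing measured here accounts for these differences.

The compounds shown leave open whether the silicon is needed at all, or whether a simple hydroxymethyl group or a butyl chain at this position would give a similar number. They also leave open how an amine in this place would read out in this assay.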